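The source may hold more compounds than are shown below. What is called first, only, known or untested is meant among the compounds shown, and "the series" means these compounds.

Measured so far:
Compound 1, `COc1ccc(C2=NN(C3=NC(=O)/C(=C4\C(=O)Nc5ccc(Cl)cc54)S3)C(c3ccc(OC)cc3)C2)cc1`: 380 nM
Compound 2, `COc1ccc(C2=NN(C3=NC(=O)/C(=C4\C(=O)Nc5ccccc54)S3)C(c3ccc(Cl)cc3)C2)cc1`: 100000 nM
Compound 3, `COc1ccc(C2=NN(C3=NC(=O)/C(=C4\C(=O)Nc5ccc(Br)cc54)S3)C(c3ccc(Cl)cc3)C2)cc1`: 340 nM

Each of these numbers comes from a functional assay on cells (Melanoma cell, Homo sapiens) for cytotoxicity, read by sulforhodamine B assay, with a stated time of 48 h; on this read-out lower numbers stand for stronger inhibition of growth and higher numbers for weaker inhibition of growth. Among the three, compound 3 gives the lowest number, at 340 nM. Compound 1, with 380 nM, lies within the usual scatter of compound 3, so the two cannot be ranked against each other. Compound 2 stands far from both: the step of a 290-fold lower number from compound 2 to compound 3 (2.47 log units; beyond the scatter) shows how much the number fell when bromo replaced hydrogen on an aromatic carbon.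

Compound 4, `COc1ccc(C2=NN(C3=NC(=O)/C(=C4\C(=O)Nc5ccc(Cl)cc54)S3)C(c3ccc(Cl)cc3)C2)cc1`, has not yet been measured. It differs from compound 3 in one place: chloro in place of bromo on an aromatic carbon. Going by the values given here, no measured pair differs by exactly this exchange. The step of a 290-fold lower number from compound 2 to compound 3 (2.47 log units; beyond the scatter) shows that bromo in place of hydrogen at that carbon mattered greatly, but it says nothing about swapping bromo for chloro. Compound 1 already carries chloro there and gives 380 nM, close to compound 3 at 340 nM, though compound 1 also differs from compound 3 in a second place. Taken together, the swap is expected to shift the number by a 1.0-fold higher number from compound 3 to compound 4 (0.01 log units; within the scatter), within the scatter. Compound 4 is therefore estimated at 350 nM, with a range from 150 nM to 850 nM.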

Compound 4, concentration for total growth inhibition: 440 nM
The estimate for compound 4 lay 1.3-fold (0.10 log units) below the measured number, within the range that was stated.
By their numbers in this assay, from the lowest: compounds 3, 1 and 4 (each within the scatter of the next); then compound 2.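

In this assay the exchange of bromo for chloro on this carbon of the fused system gives a 1.3-fold higher number from compound 3 to compound 4 (0.11 log units; within the scatter) and stays within the scatter, so the two halogens cannot be told apart at this position. Chloro also brings a large change when it replaces hydrogen there, with a 230-fold lower number from compound 2 to compound 4 (2.36 log units; beyond the scatter) of a size close to that of the bromo step, a 290-fold lower number from compound 2 to compound 3 (2.47 log units; beyond the scatter), so the sharp drop seen earlier is not unique to bromo, and the third step, a 1.2-fold higher number from compound 1 to compound 4 (0.06 log units; within the scatter), shows that chloro in place of methoxy at an aromatic carbon elsewhere in the molecule also stays within the scatter. Nothing available explains why hydrogen stands so far from both halogens at this carbon.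

As far as these compounds go, only hydrogen, chloro and bromo appear at this carbon, so it remains open how fluoro, an amine or a carboxylic acid would behave there. From the compounds shown here alone, it is also open whether the large step from hydrogen to halogen would hold at the other carbons of this ring, or with methoxy in place of chloro elsewhere in the molecule.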